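Swapping the linker on a benzimidazole thioether series

The compounds below may be only part of what the source reports. "The series", "measured", "known", "first", "only" and "open" are said of these compounds alone.

Measured so far:
compound 1, `Clc1ccc2[nH]c(SCc3ccccc3/C=C\c3ccccc3)nc2c1`: 49%
compound 2, `[O-][S+](Cc1ccccc1)c1ccccc1CSc1nc2cc(Cl)ccc2[nH]1`: 11%

For the measured compounds named here, in an assay on isolated protein for inhibition of Indoleamine 2,3-dioxygenase 1 (Homo sapiens), with a stated time of 60 min, tested at 10 uM (a higher number here means more inhibition at the concentration tested (going by the name of the read-out), a lower number less inhibition), compound 2 gives the lowest of the two numbers, with compound 1 as its only neighbour, a step of a number 38 percentage points lower from compound 1 to compound 2 (beyond the scatter) away. Compound 3, `Clc1ccc2[nH]c(SCc3ccccc3OCc3ccccc3)nc2c1`, differs from compound 2 by a group of 8 heavy atoms (7 carbon, 1 oxygen; one six-membered aromatic ring of carbon only) in place of a group of 9 heavy atoms (7 carbon, 1 oxygen, 1 sulfur; one six-membered aromatic ring of carbon only), on an aromatic carbon. Going by the values given here, only one measured step exists, and it bears only loosely on this change: there the group with the sulfur entered in place of an all-carbon group and inhibition fell sharply, a number 38 percentage points lower from compound 1 to compound 2 (beyond the scatter). Among the compounds with values here, compound 3 gives that sulfur-containing group up again for a benzyloxy, so a move back toward compound 1 is expected, though the new group is not the one compound 1 carries and the size is uncertain. Compound 3 is therefore estimated at 30% (range 10% to 55%), an expected step of a number 19 percentage points higher from compound 2 to compound 3 (beyond the scatter).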

Compound 3, a percentage reported as inhibition, at one concentration (the size of the read-out at that concentration, not a potency): 3%
For compound 3 the middle estimate is 27 percentage points above the measured one, and the stated range ends above it.
By their numbers in this assay, from the lowest: compounds 3 and 2 (each within the scatter of the next); then compound 1.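

In this assay, putting benzyloxy in place of the sulfur-containing group of compound 2 gives a number 8 percentage points lower from compound 2 to compound 3 (within the scatter), so at this position the two groups cannot be told apart. Benzyloxy in place of 2-phenylethenyl gives a number 46 percentage points lower from compound 1 to compound 3 (beyond the scatter), which shows that the large fall seen earlier is not specific to the sulfur-containing group, and that among these three compounds only the 2-phenylethenyl compound stands apart. Nothing available explains why these groups behave as they do.

The compounds shown leave open whether the carbon-carbon double bond of 2-phenylethenyl matters, or whether a saturated 2-phenylethyl group would serve as well. They also leave open how a nitrogen link, as in a benzylamino group, would compare on this aromatic carbon.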